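Aryl swap on the acetylated core

The source may report more compounds than this note shows. Statements on the series, on what has been measured and on what is new or still open speak of the compounds shown alone.

- compound 1 `COc1ccc(-c2cn(C(=O)Nc3cc(OC)c(OC)c(OC)c3)c(=O)n2-c2cc(OC)c(OC)c(OC)c2)cc1N` gives > 50000 nM as a limit
- compound 2 `COc1cc(-n2c(-c3ccc(Br)cc3)cn(C(C)=O)c2=O)cc(OC)c1OC` gives 3800 nM

Among the measured compounds shown here, in a functional assay on ECa-109 cells (Homo sapiens) for cytotoxicity, read by MTT assay, with a stated time of 48 h (on this read-out higher numbers stand for weaker inhibition and lower numbers for stronger inhibition), compound 2 gives the only actual number, 3800 nM, so nothing yet ranks it. Compound 3 `COc1ccc(-c2cn(C(C)=O)c(=O)n2-c2cc(OC)c(OC)c(OC)c2)cc1N` carries 3-amino-4-methoxyphenyl in place of the 4-bromophenyl of compound 2 on an aromatic carbon (3-amino-4-methoxyphenyl in place of 4-bromophenyl on an aromatic carbon). Compound 1 also bears 3-amino-4-methoxyphenyl, and its value is a limit, > 50000 nM. For the measured compounds named here, no measured step isolates this change, so a moderate move toward stronger inhibition in this assay is expected only tentatively. The expected size is a 7.6-fold lower number from compound 2 to compound 3 (0.88 log units; beyond the scatter) as an estimate. For compound 3 the estimated value is 500 nM, with a range of 30 nM to 8000 nM.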

Compound 3, half-maximal inhibitory concentration: > 50000 nM
Compound 3 was reported as a limit; the forecaster's own chance of this, stated with the estimate: 8%; at least 100-fold (2.00 log units) between middle value and limit.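

In this assay, 3-amino-4-methoxyphenyl in place of 4-bromophenyl on this aromatic carbon gives an at least 13-fold higher number from compound 2 to compound 3 (1.11 log units; beyond the scatter), so on the acetylated core the number depends strongly on this aryl group. Compound 3 gives > 50000 nM, which is a limit, so the step reads only as a lower bound: the limit of > 50000 nM in this assay, at which 2 of the 3 values shown sit.

Going by these compounds, whether the amino or the methoxy substituent drives the loss remains open, and 3-aminophenyl or 4-methoxyphenyl at this position would separate them. Compound 1 and compound 3 both stand at a limit, so the pair cannot be read for any effect of the group on the ring nitrogen.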